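This account rests on a few compounds, and the source may have more. Where it says the series, first, only, none or still open, it means among the compounds named here.

Measured so far in a functional assay on HepG2 cells (Homo sapiens) for inhibition, read by CCK-8 assay, with a stated time of 72 h, tested at 20 uM; a higher number here means more inhibition of growth at the concentration tested, a lower number less inhibition of growth:
compound 1, `CC(C)(C)OC(=O)/C=C1/C(=O)Nc2ccccc21`: 86.1%
compound 2, `Cc1ccc2c(c1)/C(=C\C(=O)OC(C)(C)C)C(=O)N2`: 90.3%
compound 3, `CCCCc1ccc2c(c1)/C(=C\C(=O)OC(C)(C)C)C(=O)N2`: 90.3%

Compound 3 stands level with compound 2, as no change at the digits printed from compound 2 to compound 3 (within the scatter) shows, and compound 1 lies close by, since a number 4.2 percentage points higher from compound 1 to compound 3 (within the scatter) is within the scatter. Compound 4, `CC(C)(C)OC(=O)/C=C1/C(=O)Nc2ccc(OC(F)(F)F)cc21`, differs from compound 3 in one place: trifluoromethoxy in place of butyl on an aromatic carbon. Going by the values given here, the steps that bear on this change are those at the same aromatic carbon, a number 4.2 percentage points higher from compound 1 to compound 2 (within the scatter) and a number 4.2 percentage points higher from compound 1 to compound 3 (within the scatter), both within the scatter, so the site has so far tolerated hydrogen, methyl and butyl without a clear effect. Among the compounds with values here, no measured step introduces trifluoromethoxy. Compound 4 is therefore expected to give about 86% in this assay, between 68% and 95%, a step of a number 4.3 percentage points lower from compound 3 to compound 4 (within the scatter) that is expected to stay within the scatter.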

Compound 4, percent growth inhibition at one concentration: 88.4%
Compound 4: the middle estimate sits 2.4 percentage points below what was measured; measured number inside the range.
By their numbers in this assay, from the lowest: compounds 1, 4, 2 and 3 (each within the scatter of the next).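

In this assay, trifluoromethoxy brings oxygen and fluorine to this aromatic carbon, yet all three steps stay within the scatter: a number 1.9 percentage points lower from compound 3 to compound 4 (within the scatter), a number 1.9 percentage points lower from compound 2 to compound 4 (within the scatter) and a number 2.3 percentage points higher from compound 1 to compound 4 (within the scatter). The position therefore accommodates this group as well as hydrogen, methyl and butyl, with no clear effect on growth inhibition at the one concentration tested. No available evidence accounts for this tolerance. Going by these compounds, it remains open whether an amine, a carboxylic acid or a longer chain at this carbon would leave the number unchanged. Differences among these compounds at lower concentrations also remain open.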